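The source may report more compounds than this note shows. Statements on the series, on what has been measured and on what is new or still open speak of the compounds shown alone.

Measured so far in a functional assay on CHO cells for antagonist activity at corticotropin-releasing factor receptor 1 (Homo sapiens), read by cAMP accumulation; on this read-out lower numbers stand for stronger inhibition and higher numbers for weaker inhibition:
- compound 1 `CCCCN(CC)c1nc(C)nc2c1c(C)nn2-c1c(C)cc(C)cc1C`: 9 nM
- compound 2 `CCCNCc1nc(Nc2nc(C)nc3c2c(C)nn3-c2ccc(OC)cc2C)no1`: 124 nM
- compound 3 `CCCNCc1nccn1Nc1nc(C)nc2c1c(C)nn2-c1ccc(OC)cc1C`: 400 nM

Compound 3 gives the highest number of the three in this assay. Going by the values given here, its nearest neighbour is compound 2, and the only single-place step available, a 3.2-fold higher number from compound 2 to compound 3 (0.51 log units; beyond the scatter), puts compound 3 beyond the scatter above compound 2. Among the compounds with values here, compound 1, carrying a dialkylamino group and a different aryl group on the shared core, stands furthest from compound 3 and differs from it in more than one place, so it gives no counted step.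

Compound 4 `CCC[C@@H](CO)Nc1nc(C)nc2c1c(C)nn2-c1ccc(OC)cc1C` is the next candidate. The change is 1-(hydroxymethyl)butyl in place of 2-((propylamino)methyl)-1H-imidazol-1-yl on a nitrogen on an aromatic ring. Within the data shown here, no measured step covers this exchange: the one step on record swaps one five-membered ring for another, while here the ring leaves altogether and an open chain with a hydroxyl enters. Compound 1 shows that an open-chain substituent on that nitrogen can sit at the low end of the range, but its aryl group is not the same. The expectation is therefore a lower number for compound 4 than for compound 3, with a step of about a 13-fold lower number from compound 3 to compound 4 (1.12 log units; beyond the scatter) in this assay, though the support is indirect. Compound 4 is estimated at 30 nM in this assay, within a range of 8 nM to 150 nM.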

Compound 4, inhibition constant: 574 nM
Beside the measured number, compound 4's estimate is 19-fold (1.28 log units) below it; measured number outside the range, above it.
By their numbers in this assay, from the lowest: compound 1; then compound 2; then compounds 3 and 4 (each within the scatter of the next).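

In this assay, 1-(hydroxymethyl)butyl on a nitrogen on an aromatic ring cannot be told apart from 2-((propylamino)methyl)-1H-imidazol-1-yl at this position, with a 1.4-fold higher number from compound 3 to compound 4 (0.16 log units; within the scatter), so here the loss of the five-membered aromatic ring, and the change from 10 heavy atoms to 6, leaves no readable difference. Against 5-((propylamino)methyl)-1,2,4-oxadiazol-3-yl, the same open chain gives a 4.6-fold higher number from compound 2 to compound 4 (0.67 log units; beyond the scatter), so among compound 2, compound 3 and compound 4, only the oxadiazole-bearing compound 2 stands apart, with the lowest number of the three. No measurement here accounts for either step.

Still open, as far as these compounds go, is how much the hydroxyl of the open chain and its defined stereocentre contribute, which a methyl ether in place of the hydroxyl or the opposite stereocentre would address in a single-place comparison with compound 4. Going by these compounds alone, also open is whether a dialkylamino group such as the one in compound 1 carries its number over to the aryl group shared by compound 2, compound 3 and compound 4, since compound 1 differs from each of them in more than one place.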